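A few compounds are considered here, and "the series" means these few. Any claim that something is new, unique, unknown or untested is made for them only; others in the source may bear on it.

Compound 2 `COc1ccc(CCSc2nc3c(c(=O)n(C)c(=O)n3C)n2C)cc1` was examined in an assay on microsomes for inhibition of Amine oxidase [flavin-containing] B (Homo sapiens), read by fluorescence and spectrophotometry, with a stated time of 20 min (a higher number here means a weaker inhibitor, a lower number a stronger inhibitor), where compound 2 gives 23 nM. Its nearest relative among the measured compounds is compound 1 `Cn1c(=O)c2c(nc(SCCc3ccc(Br)cc3)n2C)n(C)c1=O`, which in this assay gives 19 nM. Going by the values given here, of the two numbers known so far, the one for compound 2 is the higher, but the two lie within the scatter of each other, so in practice they are the same. Among the compounds with values here, the only measured step is the one between these two compounds, a 1.2-fold higher number from compound 1 to compound 2 (0.08 log units; within the scatter), and it is the one that bears on the change considered next. Compound 3 `Cn1c(=O)c2c(nc(SCCc3cccc(Br)c3)n2C)n(C)c1=O` differs from compound 2 by 3-bromophenyl in place of 4-methoxyphenyl on a saturated chain carbon, two bonds along the chain from a sulfur. Bromine thus appears again, as it does in compound 1, though now as part of a 3-bromophenyl. Because a 1.2-fold higher number from compound 1 to compound 2 (0.08 log units; within the scatter) stayed within the scatter, no step beyond the scatter is expected from this change either. Compound 3 is therefore estimated to give 22 nM in this assay, with a likely range from 8 nM to 60 nM. This estimate corresponds to an expected step of a 1.0-fold lower number from compound 2 to compound 3 (0.02 log units; within the scatter).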

Compound 3, half-maximal inhibitory concentration: 40 nM
Estimate against measurement, compound 3: 1.8-fold (0.26 log units) below; measured number inside the range.
By their numbers in this assay, from the lowest: compounds 1, 2 and 3 (each within the scatter of the next, the first and the last beyond it).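

In this assay, going by these compounds alone, the one step that clearly separates two compounds is the one that changes only where the bromine sits, with 3-bromophenyl in place of 4-bromophenyl on the saturated chain carbon (a 2.1-fold higher number from compound 1 to compound 3 (0.32 log units; beyond the scatter)), and this is a modest weakening. For these two bromine compounds, then, the place of the bromine on the ring makes a small but readable difference, something the earlier swap of bromo for methoxy did not show, as that step stayed within the scatter. Compound 3 nevertheless cannot be told apart from compound 2 (a 1.7-fold higher number from compound 2 to compound 3 (0.24 log units; within the scatter)), so replacing 4-methoxyphenyl with 3-bromophenyl gives no real difference, and nothing available explains either result.

The compounds shown leave open whether a methoxy group would respond to the same shift on the ring as bromine does, so this single pair cannot be taken as a general rule for the position. They also leave open how a chloro group, an amine or a carboxylic acid on the ring would compare, and what a longer chain to the sulfur would do.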